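A few compounds are considered here, and "the series" means these few. Any claim that something is new, unique, unknown or untested is made for them only; others in the source may bear on it.

Measured so far in a functional assay on HeLa cells (Homo sapiens) for cytotoxicity, read by WST assay, with a stated time of 48 h; on this read-out lower numbers stand for stronger inhibition and higher numbers for weaker inhibition
compound 1 `COc1cc(C(c2ccc(O)c(OC)c2)[C@H](C)C(C)C)ccc1O` gives 16000 nM
compound 2 `COc1cc(C(c2ccc(O)c(OC)c2)[C@H](C)[C@H](C)CO)ccc1O` gives > 100000 nM (a limit of the assay)
compound 3 `COC[C@H](C)[C@@H](C)C(c1ccc(O)c(OC)c1)c1ccc(O)c(OC)c1` gives 77000 nM

Compound 2 stands only at a limit of the assay and has no number (the limit of > 100000 nM in this assay, at which 1 of the 3 values shown sits). Compound 4 `COc1cc(C(c2ccc(O)c(OC)c2)[C@@H](CO)C(C)C)ccc1O` differs from it by 1-(hydroxymethyl)-2-methylpropyl in place of 2-(hydroxymethyl)-1-methylpropyl on a saturated chain carbon bound to two aromatic carbons and so has 1-(hydroxymethyl)-2-methylpropyl in place of 2-(hydroxymethyl)-1-methylpropyl on a saturated chain carbon bound to two aromatic carbons.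

Within the data shown here, no measured step makes this change, so the evidence is indirect. Methoxy on compound 1 gave a step beyond the scatter (a 4.8-fold higher number from compound 1 to compound 3 (0.68 log units; beyond the scatter)). The floor of the step between the two oxygen-bearing compounds lies within the scatter (an at least 1.2-fold lower number from compound 2 to compound 3 (0.11 log units; that floor lies within the scatter)). Hydroxy on compound 1 also gave a step beyond the scatter (an at least 6.2-fold higher number from compound 1 to compound 2 (0.79 log units; beyond the scatter)), and compound 4 keeps that hydroxy, so a weak reading in this assay is expected.

A modest move to a lower number is expected (an at least 1.6-fold lower number from compound 2 to compound 4 (0.22 log units; that floor lies within the scatter)), though a reading at the limit remains possible. For compound 4 the estimated value is 60000 nM as a working figure. The estimated range for compound 4 runs from 20000 nM to 150000 nM as expected bounds.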

Compound 4, half-maximal inhibitory concentration: > 100000 nM
Compound 4: only a limit was reported; the forecaster's own chance of this, stated with the estimate: 35%; middle value at least 1.6-fold (0.22 log units) from the limit.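

In this assay compound 4 also gives only a limit and not a number, so the second hydroxy-bearing arrangement on the saturated chain carbon bound to two aromatic carbons ends at the same limit as compound 2: the limit of > 100000 nM in this assay, at which 2 of the 4 values shown sit. Replacing 1,2-dimethylpropyl with 1-(hydroxymethyl)-2-methylpropyl gives an at least 6.2-fold higher number from compound 1 to compound 4 (0.79 log units; beyond the scatter), so the loss beyond the scatter seen with the hydroxy of compound 2 also holds with the hydroxymethyl placed differently on the chain. The other steps give no ranking: replacing 2-(methoxymethyl)-1-methylpropyl gives an at least 1.2-fold higher number from compound 3 to compound 4 (0.11 log units; that floor lies within the scatter), and the step between the two limits cannot be read.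

Going by these compounds, how far compound 2 and compound 4 lie past the limit remains open. Also open, on these data alone, is whether an amine in place of the hydroxy, or a longer chain carrying it, would read closer to compound 1 at 16000 nM.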